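This account rests on a few compounds, and the source may have more. Where it says the series, first, only, none or still open, it means among the compounds named here.

In a physicochemical assay for metabolic stability, read by LC-MS, with a stated time of 38 days, tested at 10 mM (on this read-out lower numbers stand for a less stable compound and higher numbers for a more stable compound), compound 1 (`O=C(Nc1nnc(-c2ccncc2)s1)c1cc(-c2ccco2)nc2ccccc12`) gives 101% and compound 2 (`O=C(Nc1nnc(-c2ccncc2)s1)c1ccnc(-c2ccco2)c1`) gives 90% on the same read-out. Compound 3 (`Cc1ccc(-c2ccc3ccccc3n2)o1`) gives 102% in that test. This places it level with compound 1 within the scatter, while the gap down to compound 2 lies beyond the scatter. The account now turns to compound 4 (`c1coc(-c2ccc3ccccc3n2)c1`), which differs from compound 3 in one place, with hydrogen in place of methyl on an aromatic carbon. For the measured compounds named here, no measured pair shows this exchange, so the data offer no direct guide to its size. The expectation rests only on the three values, which all stay high, with compound 2 at 90% as the lowest of them. In this assay, the estimated step of a number 4 percentage points lower from compound 3 to compound 4 (within the scatter) is expected to stay within the scatter, with only a slight lean downward. Compound 4 is expected to read 98% (estimated range 88% to 105%) when it is measured.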

Compound 4, percent of the compound remaining: 117%
Compound 4: middle estimate off by 19 percentage points, on the low side; the measured number lies above the stated range.
By their numbers in this assay, from the lowest: compound 2; then compounds 1 and 3 (each within the scatter of the next); then compound 4.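

In this assay, hydrogen in place of methyl on the aromatic carbon next to the ring oxygen gives a number 15 percentage points higher from compound 3 to compound 4 (beyond the scatter), so a change of a single heavy atom at this position can move the number beyond the scatter. For the compounds shown here, the earlier compounds offered no pair differing in one place, which makes this the first step that can be read, though it remains a single step on a single core. Nothing in the data at hand accounts for the direction or the size of this step.

From the compounds shown here alone, whether an amine or a longer chain on that same carbon would read closer to the methyl or to the hydrogen stays open. Going by these compounds, it is also open whether the same exchange would give a step of similar size on the core of compound 1.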